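The compounds below may be only part of what the source reports. "The series", "measured", "known", "first", "only" and "open" are said of these compounds alone.

Measured so far:
compound 1 `CN(C)c1ccc(/C=C(/Sc2ccc(Br)cc2)C(=O)c2ccc(Cl)cc2)cc1` — > 100000 nM
compound 2 `Cc1ccc(S/C(=C/c2ccc(Cl)c(Cl)c2)C(=O)c2ccc(Br)cc2)cc1` — 50000 nM
compound 3 `COc1ccccc1/C=C(\C(=O)c1ccc(Cl)cc1)S(=O)(=O)Cc1ccc(Cl)cc1` — 25000 nM

In a functional assay on DU-145 cells (Homo sapiens) for inhibition, read by trypan blue exclusion, with a stated time of 96 h (on this read-out higher numbers stand for weaker inhibition of growth and lower numbers for stronger inhibition of growth), compound 1 gives only a limit, > 100000 nM, as shown by the limit of > 100000 nM in this assay, at which 1 of the 3 values shown sits. Compound 2 gives 50000 nM in this assay, and compound 3 gives 25000 nM; these two numbers lie within the scatter of each other, so no order can be read between them, and compound 2 stands alongside compound 3 among the numbered values. Compound 4 `Cc1ccc(S/C(=C/c2ccc(F)c(C)c2)C(=O)c2ccc(Br)cc2)cc1` has not yet been measured in this assay. It differs from compound 2 in one place: 4-fluoro-3-methylphenyl in place of 3,4-dichlorophenyl on a double-bonded chain carbon bound to a double-bonded chain carbon. Among the measured compounds shown here, with no measured step of this kind available, the step of a 1.2-fold higher number from compound 2 to compound 4 (0.08 log units; within the scatter) is expected to be small, not beyond the scatter. Compound 4 is therefore estimated at 60000 nM, within a range from 20000 nM to 150000 nM.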

Compound 4, concentration for 50% growth inhibition: 25000 nM
Compound 4: middle estimate off by 2.4-fold (0.38 log units), on the high side; measured number inside the range.
By their numbers in this assay, from the lowest: compounds 3, 4 and 2 (each within the scatter of the next). At a limit, above all of these: compound 1.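

Among the compounds shown here, the exchange of 3,4-dichlorophenyl for 4-fluoro-3-methylphenyl on a double-bonded chain carbon bound to a double-bonded chain carbon gives the first step that can be read at this position in this assay: a 2.0-fold lower number from compound 2 to compound 4 (0.30 log units; within the scatter). The two rings therefore cannot be told apart here, and the second chlorine atom is not required for a number in this range. Nothing available bears on the cause of this step. The compounds shown leave open whether an amine or a carboxylic acid on this ring would give a step beyond the scatter.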